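Lipophilicity notes on the dichloro lactam series

A few compounds are considered here, and "the series" means these few. Any claim that something is new, unique, unknown or untested is made for them only; others in the source may bear on it.

Compound 1 `Cc1cc(C)c(CN2CCc3c(Cl)cc([C@@H](CO)[C@@H]4CCOC4)c(Cl)c3C2=O)c(=O)[nH]1` is the reference point. In a physicochemical assay for lipophilicity, at pH 7.4 (on this read-out lower numbers stand for lower lipophilicity and higher numbers for higher lipophilicity), compound 1 gives 2, the only number shown for it alongside one further entry without a single number. Compound 2 `COC(c1cc(Cl)c2c(c1Cl)C(=O)N(Cc1c(C)cc(C)[nH]c1=O)CC2)C1CCN(C2COC2)CC1` belongs to the same set; in this assay compound 2 gives 2.7; 2.8 (2 entries), and the repeated entries the several entries of compound 2 in this assay, 2.7; 2.8 (2 entries) sit close together. Going by the values given here, no step between measured compounds is available, so the pair of compounds 1 and 2 is read only as two separate values.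

Compound 3 `Cc1cc(C)c(CN2CCc3c(Cl)cc([C@@H](C)CO)c(Cl)c3C2=O)c(=O)[nH]1` differs from compound 1 in one place: a group of 4 heavy atoms (3 carbon, 1 oxygen; no ring) in place of a group of 8 heavy atoms (6 carbon, 2 oxygen; one five-membered non-aromatic ring with 1 hetero atom), on an aromatic carbon. A group of 4 heavy atoms replaces a group of 8 heavy atoms on the aromatic carbon ortho to a chloro group. Among the compounds with values here, with no measured step to lean on, the expected change from compound 1 to compound 3, a number 0.10 log units lower from compound 1 to compound 3 (within the scatter), is estimated to lie within the scatter, if anything slightly downward. Compound 3 is expected to give 1.9, with a range of 1.4 to 2.4.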

Compound 3, distribution coefficient: 2.5
For compound 3 the middle estimate is 0.60 log units below the measured one, and the stated range ends below it.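

Exchanging the group carrying the five-membered non-aromatic ring for 1-(hydroxymethyl)ethyl, on the aromatic carbon ortho to a chloro group, gives the first step read at this position, in this assay: a number 0.50 log units higher from compound 1 to compound 3 (beyond the scatter). The exchange removes the ring and reduces the heavy-atom count in a single change, so these two differences cannot be separated here. The only repeated entries shown come from another compound and sit close together: the several entries of compound 2 in this assay, 2.7; 2.8 (2 entries)

Still open, going by these compounds, is whether the step follows from losing the ring or from the smaller group as a whole, which a longer open chain ending in the same hydroxyl could help to separate. Also open, on these data alone, is how the read-out responds at this position when an amine or a carboxylic acid takes the place of that hydroxyl.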